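The source may hold more compounds than are shown below. What is called first, only, known or untested is meant among the compounds shown, and "the series" means these compounds.

Measured in a functional assay on HEL cells (Homo sapiens) for cytotoxicity; a higher number here means that more compound is tolerated, a lower number that less compound is tolerated:
Compound 1 `CCCCCCc1cc2cn([C@H]3C[C@H](O)[C@@H](CO)O3)c(=O)nc2o1`: > 200000 nM, a limit.
Compound 2 `CCCCCCCCCCc1cc2cn([C@H]3C[C@H](O)[C@@H](CO)O3)c(=O)nc2o1`: > 50000 nM, a limit.

Compound 1 has no exact number in this assay and stands only at the limit of > 200000 nM in this assay, at which 1 of the 2 values shown sits. Compound 3 `C=CCCCCCCc1cc2cn([C@H]3C[C@H](O)[C@@H](CO)O3)c(=O)nc2o1` differs from it by vinyl in place of hydrogen on a saturated chain carbon, six bonds along the chain from an aromatic carbon. Going by the values given here, the one measured step at that same place has butyl entering instead of vinyl, and it is a step that the two limits leave unreadable from compound 1 to compound 2. Compound 2 stands at the limit of > 50000 nM in this assay, at which 1 of the 2 values shown sits. That step therefore offers no size to carry over, and neither limit points to a direction. No step beyond the usual scatter is expected, so the estimated change is an at least 1.3-fold lower number from compound 1 to compound 3 (0.12 log units; that floor lies within the scatter). Compound 3 is expected to give about 150000 nM, with an estimated range of 50000 nM to 300000 nM.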

Compound 3, half-maximal cytotoxic concentration: > 200000 nM
Compound 3 ended at the assay's limit; the forecaster's own chance of this, stated with the estimate: 75%; middle value at least 1.3-fold (0.12 log units) away from the limit.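

Compound 3 gives > 200000 nM, which is a limit. All three values are limits, so the steps from compound 1 and from compound 2 to compound 3 cannot be read. The compounds shown leave open whether the vinyl or butyl change shifts the tolerated concentration at all in this assay, with no exact number for any of them.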